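Amide substituent change on the phenyl-bearing core

The compounds below may be only part of what the source reports. "The series", "measured", "known", "first", "only" and "open" are said of these compounds alone.

Measured compounds:
Compound 1 `CCNC(=O)c1oc2nc(-c3ccccc3)cc(C(F)(F)F)c2c1N` in a functional assay on HepG2 cells (Homo sapiens) for antiproliferative activity, read by MTT assay; on this read-out higher numbers stand for weaker inhibition and lower numbers for stronger inhibition: 42800 nM
Compound 2 `Nc1c(C(=O)N/N=C/c2ccc(Br)cc2)oc2nc(-c3cccs3)cc(C(F)(F)F)c12`: 6100 nM
Compound 3 `CCCNC(=O)c1oc2nc(-c3cccs3)cc(C(F)(F)F)c2c1N`: 17200 nM

Compound 1 gives the highest number of the three; compound 3 stands a step lower and compound 2 lower still. Compound 4 `Nc1c(C(=O)N/N=C/c2ccc(Br)cc2)oc2nc(-c3ccccc3)cc(C(F)(F)F)c12` differs from compound 1 by a group of 9 heavy atoms (7 carbon, 1 nitrogen, 1 bromine; one six-membered aromatic ring of carbon only) in place of a group of 2 heavy atoms (2 carbon; no ring), on an amide-type nitrogen. Within the data shown here, the one measured step that bears on this change is a 2.8-fold higher number from compound 2 to compound 3 (0.45 log units; beyond the scatter), which runs in the opposite direction on a closely related core. Read in reverse, that step suggests the entering group lowers the number, so the step from compound 1 to compound 4 is expected to be a 3.1-fold lower number from compound 1 to compound 4 (0.49 log units; beyond the scatter). Compound 4 is accordingly estimated at 14000 nM, with a range of 5000 nM to 40000 nM.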

Compound 4, half-maximal inhibitory concentration: 19900 nM
Estimate against measurement, compound 4: 1.4-fold (0.15 log units) below, within the range that was stated.
By their numbers in this assay, from the lowest: compound 2; then compounds 3 and 4 (each within the scatter of the next); then compound 1.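

In this assay, the group carrying the bromine-substituted aromatic ring in place of ethyl on the amide-type nitrogen gives a 2.2-fold lower number from compound 1 to compound 4 (0.33 log units; beyond the scatter), a direct reading of this change with phenyl on the shared core. With that amide group held constant, phenyl in place of thiophen-2-yl on an aromatic carbon gives a 3.3-fold higher number from compound 2 to compound 4 (0.51 log units; beyond the scatter). No measurement available explains either step.

As far as these compounds go, whether the phenyl and thiophen-2-yl change reads the same with a simple alkyl chain on the amide-type nitrogen remains open, as compound 1 and compound 3 differ in two places. Also open, from the compounds shown here alone, is how an amine or a carboxylic acid in place of the bromine would read.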